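The compounds below may be only part of what the source reports. "The series", "measured", "known", "first", "only" and "open" are said of these compounds alone.

Compound 1 `N#Cc1ccc(Nc2nccc(Oc3ccc(-c4ccc(C#N)cc4)cc3C(F)(F)F)n2)cc1` was tested in a functional assay on MT4 cells (Homo sapiens) for cytotoxicity, read by MTT assay, with a stated time of 5 days; a lower number here means that less compound is tolerated, a higher number that more compound is tolerated. In this assay compound 1 gives > 273000 nM, which is a limit of the assay rather than a measured number. Compound 2 `COc1cc(-c2ccc(C#N)cc2)ccc1Nc1ccnc(Nc2ccc(C#N)cc2)n1`, a second member of the same series, was run in the same test. In this assay compound 2 gives > 298000 nM, again a limit and not a number. Compound 1 therefore stands at a limit, as shown by the limit of > 273000 nM in this assay, at which 1 of the 2 values shown sits, and the only other value in hand is likewise a limit, as shown by the limit of > 298000 nM in this assay, at which 1 of the 2 values shown sits; the two compounds show no measured difference between them.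

Compound 3 `Cc1cc(-c2ccc(C#N)cc2)ccc1Oc1ccnc(Nc2ccc(C#N)cc2)n1` has not yet been measured. It differs from compound 1 in one place: methyl in place of trifluoromethyl on an aromatic carbon. Going by the values given here, no measured step between two compounds is available to guide the size of this change. The step from compound 1 to compound 3 is expected to stay within the scatter, a step that the limit leaves unreadable from compound 1 to compound 3, with no movement in either direction that the assay would resolve. Compound 3 is expected to give 300000 nM in this assay, within a range from 150000 nM to 600000 nM, most likely reported again only as a limit.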

Compound 3, half-maximal cytotoxic concentration: > 310000 nM
Compound 3 was reported as a limit; the forecaster's own chance of this, stated with the estimate: 85%; at least 1.0-fold (0.01 log units) between middle value and limit.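

In this assay compound 3 gives > 310000 nM, which is a limit of the assay and not a number. Compound 1 also stands at a limit, and no step can be read between compound 1 and compound 3. The compounds shown leave open what concentration of any of them would prove cytotoxic, and whether methyl in place of trifluoromethyl changes it.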